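From a methoxy group to a larger ring-bearing group

The compounds below may be only part of what the source reports. "The series", "measured", "known", "first", "only" and "open" are said of these compounds alone.

Compound 2 `CCOC(=O)c1c(-c2cccc(OC)c2)[nH]c2cc(OC)c(F)cc2c1=O` carries a methoxy group on its aromatic ring. In an ADME assay on Raji cells (Homo sapiens) for cytotoxicity, read by luminescence, with a stated time of 72 h (on this read-out lower numbers stand for an effect already at smaller amounts and higher numbers for an effect only at larger amounts of compound), compound 2 gives only a limit, > 21500 nM. Compound 1 `CCOC(=O)c1c(-c2cccc(OC)c2)[nH]c2cc(OC)ccc2c1=O` likewise gives in this assay a limit, > 21500 nM. The step that the two limits leave unreadable from compound 1 to compound 2 is thus not readable, and the limit of > 21500 nM in this assay, at which 2 of the 2 values shown sit, is all that this pair shows. Compound 3 `CCOC(=O)c1c(-c2cccc(Cc3nc(C)c(C)s3)c2)[nH]c2cc(OC)c(F)cc2c1=O` differs from compound 2 by a group of 8 heavy atoms (6 carbon, 1 nitrogen, 1 sulfur; one five-membered aromatic ring with 2 hetero atoms) in place of a group of 2 heavy atoms (1 carbon, 1 oxygen; no ring), on an aromatic carbon. Going by the values given here, no measured step bears on this change, so no direction can be read from the data. Compound 3 is expected to give about 25000 nM, with a range from 5000 nM to 80000 nM. The estimated step is a step that the limit leaves unreadable from compound 2 to compound 3.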

Compound 3, half-maximal effective concentration: > 21500 nM
Compound 3: a limit, no number; the forecaster's own chance of this, stated with the estimate: 75%; the middle value is on the limit's open side.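

Compound 3 also gives only a limit in this assay, > 21500 nM, so no step can be read from compound 2 to compound 3. The compounds shown leave open whether either change alters the read-out at all, and all they offer is this: the limit of > 21500 nM in this assay, at which 3 of the 3 values shown sit.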